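A few compounds are considered here, and "the series" means these few. Any claim that something is new, unique, unknown or untested is made for them only; others in the source may bear on it.

Compound 1 `C[C@@H](Oc1cc2oc(=O)n(CCC(=O)O)c2cc1Cl)c1ccc(F)cn1` gives 25.1 nM in an assay on HEK293 cells for inhibition of kynurenine 3-monooxygenase (Homo sapiens), read by LC-MS, with a stated time of 20 h; a higher number here means a weaker inhibitor, a lower number a stronger inhibitor.
Compound 2 `C[C@@H](Oc1cc2onc(CCC(=O)O)c2cc1Cl)c1ccc(F)cn1` gives 31.6 nM.
Compound 3 `C[C@@H](Oc1cc2oc(=O)n(CCC(=O)O)c2cc1Cl)c1ccc(Cl)cn1` gives 100 nM.

Compound 3 stands highest of the three numbers in this assay; compound 2 is the nearest and compound 1 the furthest below it. Compound 4 `Cc1ccnc([C@@H](C)Oc2cc3oc(=O)n(CCC(=O)O)c3cc2Cl)c1` is reached from compound 3 by 4-methylpyridin-2-yl in place of 5-chloropyridin-2-yl on a saturated chain carbon bound to an oxygen on an aromatic ring and a saturated chain carbon. For the measured compounds named here, the one measured step that bears on this ring is a 4.0-fold higher number from compound 1 to compound 3 (0.60 log units; beyond the scatter), where chloro in place of fluoro raised the number by a modest amount. Going by the values given here, compound 4 loses that chloro, so the step is expected to run downward, though the entering methyl has no measured counterpart here. Compound 4 is therefore expected near 40 nM, within 15 nM to 110 nM, an estimated 2.5-fold lower number from compound 3 to compound 4 (0.40 log units; beyond the scatter).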

Compound 4, half-maximal inhibitory concentration: 31600 nM
Compound 4: the middle estimate sits 790-fold (2.90 log units) below what was measured; the measured number lies above the stated range.
By their numbers in this assay, from the lowest: compounds 1 and 2 (each within the scatter of the next); then compound 3; then compound 4.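

At this position, on a saturated chain carbon bound to an oxygen on an aromatic ring and a saturated chain carbon, the change of pyridine group matters far more than the halogen swap, which gave only a 4.0-fold higher number from compound 1 to compound 3 (0.60 log units; beyond the scatter). Replacing 5-chloropyridin-2-yl with 4-methylpyridin-2-yl, a group with the same heavy-atom count, gives a 320-fold higher number from compound 3 to compound 4 (2.50 log units; beyond the scatter), and replacing 5-fluoropyridin-2-yl gives a 1300-fold higher number from compound 1 to compound 4 (3.10 log units; beyond the scatter). Nothing measured here accounts for these steps. The compounds shown leave open whether the loss of the halogen or the entering methyl carries the steps, and where a plain pyridin-2-yl group would stand.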